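This account rests on a few compounds, and the source may have more. Where it says the series, first, only, none or still open, it means among the compounds named here.

Compound 1 `O=C1COc2ccc(-c3[nH]c(-c4ccc(F)cc4)nc3-c3ccccc3)cc2N1` is one of two measured compounds. In a functional assay on MV4-11 cells (Homo sapiens) for cytotoxicity, read by colorimetric assay and MTT assay, with a stated time of 3 days, tested at 1 uM (on this read-out higher numbers stand for a weaker effect at the one concentration tested and lower numbers for a stronger effect), compound 1 gives 108%. Compound 2 `O=C1COc2ccc(-c3nn(-c4ccc(Br)cc4)cc3-c3ccccc3)cc2N1` gives 108% in this assay, which is level with compound 1 within the scatter. Compound 3 `O=C1COc2ccc(-c3[nH]c(-c4ccccc4)nc3-c3ccccc3)cc2N1` differs from compound 1 in one place: hydrogen in place of fluoro on an aromatic carbon. Within the data shown here, with no step between measured compounds to go by, and both measured values showing only a weak effect at the tested concentration, the step from compound 1 to compound 3 in this assay is expected to be a number 3 percentage points lower from compound 1 to compound 3 (within the scatter), which is nothing beyond the scatter. Compound 3 is therefore estimated at 105%, in a range from 90% to 120%.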

Compound 3, a percentage reported as activity, at one concentration (the size of the read-out at that concentration, not a potency): 105%
Compound 3: the middle estimate sits on the measured number at the digits printed; low and high end bracket the measured number.
By their numbers in this assay, from the lowest: compounds 3, 1 and 2 (each within the scatter of the next).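

In this assay, among these compounds, hydrogen in place of fluoro on an aromatic carbon gives a number 3 percentage points lower from compound 1 to compound 3 (within the scatter) and so offers the first direct comparison at this position. Going from 4-fluorophenyl to phenyl therefore makes no measurable difference to the read-out, which the two earlier compounds, differing in more than one place, could not show. No measurement here offers an explanation for this result. The compounds shown leave open whether an amine, a carboxylic acid or a methoxy group at this position would change the read-out.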